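Cytotoxicity notes on three measured analogues and one estimate

This account rests on a few compounds, and the source may have more. Where it says the series, first, only, none or still open, it means among the compounds named here.

Compound 1 `CCOc1nc(N)nc2c1ncn2/C=C1/CC1(CO)CO` in an ADME assay on BCBL1 cells (Homo sapiens) for cytotoxicity, with a stated time of 7 days (on this read-out lower numbers stand for higher toxicity in this test and higher numbers for lower toxicity in this test), gives > 20000 nM, a limit of the assay.
Compound 2 `Nc1nc(NCc2ccccc2)c2ncn(/C=C3/CC3(CO)CO)c2n1` in this assay gives 19900 nM.
Compound 3 `CCCCCCCCSc1nc(N)nc2c1ncn2/C=C1/CC1(CO)CO` in this assay gives > 20000 nM, a limit of the assay.

Within the data shown here, compound 2 is the only compound with a number; the other two values are limits. The next step is to compound 4 `CCCCCCOc1nc(N)nc2c1ncn2/C=C1/CC1(CO)CO`: hexyloxy in place of benzylamino on an aromatic carbon. Among the measured compounds shown here, two measured steps touch the same position: a number no higher from compound 1 to compound 2 (the limit leaves the size open) and a number no lower from compound 2 to compound 3 (the limit leaves the size open), neither readable in size because of the limit of > 20000 nM in this assay, at which 2 of the 3 values shown sit. The shared core with ethoxy or octylsulfanyl gave only limits, and compound 2 sits close to that limit. Compound 4 is expected at 20000 nM, with a range from 10000 nM to 40000 nM. The expected step of a 1.0-fold higher number from compound 2 to compound 4 (0.00 log units; within the scatter) is none beyond the scatter, and a limit rather than a number is as likely as not.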

Compound 4, half-maximal cytotoxic concentration: > 20000 nM
Compound 4: a limit, no number (the forecaster's own chance of this, stated with the estimate: 55%); the middle value lies on the limit itself.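

Among these compounds, with hexyloxy at this position, the shared core again gives a limit rather than a number, as it does with ethoxy and octylsulfanyl, and benzylamino remains the only group here with a number. The change from benzylamino to hexyloxy gives a number no lower from compound 2 to compound 4 (the limit leaves the size open). The steps among compound 1, compound 3 and compound 4 cannot be read: the limit of > 20000 nM in this assay, at which 3 of the 4 values shown sit.

Still open, as far as these compounds go, is whether the number with benzylamino goes with its aromatic ring or its nitrogen link. Hexylamino and phenoxy at this position would separate the two.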